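A Chloro on the Phenyl of Compound 1

A few compounds are considered here, and "the series" means these few. Any claim that something is new, unique, unknown or untested is made for them only; others in the source may bear on it.

Measured in a functional assay on the whole organism for antagonist activity, with Mus musculus as the target; on this read-out higher numbers stand for an effect only at larger amounts of compound and lower numbers for an effect already at smaller amounts:
- compound 1 `CC(=O)NCC(=O)Nc1ccc(Cl)cc1C(=O)c1ccccc1`: 37 mg/kg
- compound 2 `NC(C(=O)NCC(=O)Nc1ccc(Cl)cc1C(=O)c1ccccc1)c1ccccc1`: 28 mg/kg
- compound 3 `CCCC(=O)NCC(=O)N(C)c1ccc(Cl)cc1C(=O)c1ccccc1Cl`: 0.98 mg/kg

Compound 1 stands at the upper end of these numbers, level with compound 2 within the scatter. Compound 3 gives a much lower number, 0.98 mg/kg, against compound 1 at 37 mg/kg.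

The change of interest leads to compound 4 `CC(=O)NCC(=O)Nc1ccc(Cl)cc1C(=O)c1ccccc1Cl`, and it is chloro in place of hydrogen on an aromatic carbon, ortho to a large group, or phenyl to 2-chlorophenyl. Among the compounds with values here, the only measured step, a 1.3-fold lower number from compound 1 to compound 2 (0.12 log units; within the scatter), lies within the scatter and concerns another part of the molecule, amino(phenyl)methyl in place of methyl on a carbonyl carbon, so it says little here. Within the data shown here, no measured step isolates the chloro. Compound 3 at 0.98 mg/kg also carries the 2-chlorophenyl, but it differs from compound 4 elsewhere too, so only part of its gap can be expected to carry over. What is expected in this assay is therefore a moderate move toward a lower number, beyond the scatter, and the estimated step is a 3.7-fold lower number from compound 1 to compound 4 (0.57 log units; beyond the scatter). For compound 4 the expected value is 10 mg/kg, with an estimated range of 3 mg/kg to 30 mg/kg.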

Compound 4, dose for half-maximal effect: > 100 mg/kg
Compound 4 ended at the assay's limit (the forecaster's own chance of this, stated with the estimate: 3%); middle value at least 10-fold (1.00 log units) away from the limit.
By their numbers in this assay, from the lowest: compound 3; then compounds 2 and 1 (each within the scatter of the next). At a limit, above all of these: compound 4.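

In this assay, chloro in place of hydrogen on an aromatic carbon, ortho to a large group, proves to be far from a neutral change on the core of compound 1, giving an at least 2.7-fold higher number from compound 1 to compound 4 (0.43 log units; beyond the scatter). Compound 4 gives > 100 mg/kg, which is a limit of the assay and not a number: the limit of > 100 mg/kg in this assay, at which 1 of the 4 values shown sits. This is the only step shown that isolates phenyl to 2-chlorophenyl, and on this core it goes toward a higher number, so the low value of compound 3, 0.98 mg/kg, cannot be credited to the 2-chlorophenyl it carries.

Compound 3 differs from compound 4 in more than one place, so the compounds shown leave open whether the same chloro would give a step in the same direction with the longer chain or the methyl on the amide nitrogen of compound 3 in place, each taken alone. Also open, going by these compounds, is how a fluoro or a methoxy would read in place of the chloro at this position, and whether any group there can keep the number of compound 1, 37 mg/kg.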